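Phenyl for propyl on the ring nitrogen

A few compounds are considered here, and "the series" means these few. Any claim that something is new, unique, unknown or untested is made for them only; others in the source may bear on it.

Compound 1 `CCCc1nn(C)c2c1C(c1ccccc1Cl)=NCC(=O)N2`: > 40 mg/kg
Compound 2 `CCCn1nc(C)c2c1NC(=O)CN=C2c1ccccc1Cl`: 40 mg/kg

In a functional assay on the whole organism (strain Holtzman) with Rattus norvegicus as the target (a lower number here means that less compound is needed, a higher number that more compound is needed for the effect), compound 1 gives only a limit of the assay, (the limit of > 40 mg/kg in this assay, at which 1 of the 2 values shown sits). Within the data shown here, compound 2 gives 40 mg/kg in this assay, the only plain number among the two values. Compound 3 `Cc1nn(-c2ccccc2)c2c1C(c1ccccc1Cl)=NCC(=O)N2` has not been measured. It differs from compound 2 in one place: phenyl in place of propyl on an aromatic nitrogen. Among the measured compounds shown here, with no measured step of this kind to lean on, a change in either direction that stays within the usual scatter is expected, a 1.3-fold lower number from compound 2 to compound 3 (0.12 log units; within the scatter). For compound 3 the estimate is 30 mg/kg, between 10 mg/kg and 80 mg/kg.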

Compound 3, minimum effective dose: 20 mg/kg
Beside the measured number, compound 3's estimate is 1.5-fold (0.18 log units) above it; low and high end bracket the measured number.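

In this assay, putting phenyl in place of propyl on this aromatic nitrogen gives a 2.0-fold lower number from compound 2 to compound 3 (0.30 log units; within the scatter). So this position accepts a six-membered aromatic ring as well as an open chain, with no difference that stands clear of the scatter. Nothing measured here explains why the two groups read alike. Still open, from the compounds shown here alone, is how this nitrogen responds to a group carrying an amine or a carboxylic acid. A longer chain such as hexyl, or a phenyl ring bearing a chlorine, is equally untested in these compounds.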